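The compounds below may be only part of what the source reports. "The series", "measured", "known", "first", "only" and "open" are said of these compounds alone.

Measured compounds, where each value is a limit and not a number:

- compound 1 `COc1cc(OC)c(OC)cc1/C=C/COC(=O)/C=C/c1ccc(OC)c(OC)c1`: > 723 umol/kg
- compound 2 `COc1cc(OC)c(OC)cc1/C=C/COC(=O)/C=C/c1c(OC)ccc(OC)c1OC`: > 674 umol/kg
- compound 3 `COc1cc(OC)c(OC)cc1/C=C/COC(=O)/C=C/c1cc(OC)c(OC)c(OC)c1OC`: > 421 umol/kg

All of these come from a functional assay on the whole organism (strain Kunming) with Mus musculus as the target, with a stated time of 0.5 h; a higher number here means that more compound is needed for the effect, a lower number that less compound is needed. Compound 1 has no exact dose for half-maximal effect, only the limit (the limit of > 723 umol/kg in this assay, at which 1 of the 3 values shown sits). Among the measured compounds shown here, the other two compounds also have only limits, so none of the three can be ranked against the others, and no measured step exists to use as a guide.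

The next compound is compound 4 `COc1cc(OC)c(OC)cc1/C=C/COC(=O)/C=C/c1ccc(F)cc1`, which has 4-fluorophenyl in place of 3,4-dimethoxyphenyl on a double-bonded chain carbon bound to a double-bonded chain carbon. The rest of the core of compound 1 stays the same.

For the measured compounds named here, with no measured step to lean on, no change beyond the usual scatter is expected in this assay, in either direction. The expected change is an at least 1.0-fold lower number from compound 1 to compound 4 (0.01 log units; that floor lies within the scatter). Another limit rather than a number is a real possibility. For compound 4 the estimated dose for half-maximal effect is 700 umol/kg, with an expected range from 300 umol/kg to 1500 umol/kg.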

Compound 4, dose for half-maximal effect: > 805 umol/kg
Compound 4: a limit, no number (the forecaster's own chance of this, stated with the estimate: 60%); middle value at least 1.1-fold (0.06 log units) away from the limit.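

Compound 4 gives [ > 805 umol/kg ], a limit and not a number. Compound 1 also has only a limit, so no step can be read between compound 1 and compound 4. Going by these compounds, whether 4-fluorophenyl in place of 3,4-dimethoxyphenyl changes the dose needed stays open.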